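The source may report more compounds than this note shows. Statements on the series, on what has been measured and on what is new or still open speak of the compounds shown alone.

Compound 1, `CC1CC=C(C(=O)N(c2cc(C#CC(C)(C)C)sc2C(=O)O)C(C)C)CC1`, gives 0.08 in an ADME assay for protein binding, using equilibrium dialysis, at pH 7.4, tested at 2 uM; a higher number here means a larger unbound share of the compound, a lower number a smaller unbound share.
Compound 2, `CON=C1CCC(N(c2cc(C#CC(C)(C)C)sc2C(=O)O)C(=O)[C@H]2CC[C@H](C)CC2)CC1`, gives 0.07 in this assay .

Of these two numbers compound 1 has the higher one, yet the gap to compound 2 lies within the usual scatter, so the two compounds cannot be told apart here. Compound 3, `CC(C)N(C(=O)[C@H]1CC[C@@H]2C[C@@H]2CC1)c1cc(C#CC(C)(C)C)sc1C(=O)O`, differs from compound 1 in one place: a group of 8 heavy atoms (8 carbon; one three-membered non-aromatic ring of carbon only, one seven-membered non-aromatic ring of carbon only) in place of a group of 7 heavy atoms (7 carbon; one six-membered non-aromatic ring of carbon only), on a carbonyl carbon. Among the compounds with values here, no measured pair shows what such a change does in this assay ; a step in either direction that stays within the scatter seems most likely. Compound 3 is therefore expected to give about 0.07, with a likely range from 0.035 to 0.14. The expected step of a 1.1-fold lower number from compound 1 to compound 3 (0.06 log units; within the scatter) is small.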

Compound 3, unbound fraction: 0.08
Compound 3: middle estimate off by 1.1-fold (0.06 log units), on the low side; measured number inside the range.
By their numbers in this assay, from the lowest: compounds 2, 1 and 3 (each within the scatter of the next).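

Swapping the 4-methylcyclohex-1-en-1-yl group on the carbonyl carbon for a group with a three-membered and a seven-membered carbon ring gives no change at the digits printed from compound 1 to compound 3 (within the scatter) in this assay. Within the data shown here, this is the first measured step at this position, and it shows that this position can take a fused-ring carbon group with 3 defined stereocentres while the unbound fraction stays within the scatter. Nothing measured here offers an explanation for this result. Still open, on these data alone, is whether a group carrying an amine or a carboxylic acid on this carbonyl carbon would move the unbound fraction. A single step also cannot show how other all-carbon groups would behave there.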